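The source may hold more compounds than are shown below. What is called first, only, known or untested is meant among the compounds shown, and "the series" means these compounds.

Measured so far in an ADME assay on Vero cells (Chlorocebus sabaeus) for cytotoxicity, read by MTT assay, with a stated time of 72 h; a higher number here means that more compound is tolerated, a lower number that less compound is tolerated:
Compound 1 `O=C(N/N=C/c1cccc(Br)c1)c1ccc([N+](=O)[O-])o1`: "not determined" (no result reported)
Compound 2 `C/C(=N\NC(=O)c1ccc([N+](=O)[O-])o1)c1ccccc1`: > 228000 nM
Compound 3 `C/C(=N\NC(=O)c1ccc([N+](=O)[O-])o1)c1ccc([N+](=O)[O-])cc1`: > 196000 nM

Compound 3 gives only a limit, > 196000 nM, and not a number. Compound 2 also gives only a limit, > 228000 nM. Compound 4 `C/C(=N\NC(=O)c1ccc([N+](=O)[O-])o1)c1ccc(Br)cc1` has bromo in place of nitro on an aromatic carbon. Among the compounds with values here, the only measured step on this ring position is a step that the two limits leave unreadable from compound 2 to compound 3, so it offers no size to carry over. With compound 3 at the limit of > 196000 nM, no change beyond the scatter is expected in this assay. The estimated step is an at least 1.1-fold lower number from compound 3 to compound 4 (0.06 log units; that floor lies within the scatter). For compound 4 the expected value is 170000 nM. The estimated range for compound 4 runs from 70000 nM to 260000 nM.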

Compound 4, half-maximal cytotoxic concentration: > 177000 nM
Compound 4 was reported as a limit; the forecaster's own chance of this, stated with the estimate: 65%; middle value at least 1.0-fold (0.01 log units) from the limit.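

Compound 2, compound 3 and compound 4 each give only a limit in this assay, and the steps among them cannot be read. The compounds shown leave open each one's actual half-maximal cytotoxic concentration, and whether hydrogen, nitro or bromo on the aromatic ring changes it.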